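The compounds below may be only part of what the source reports. "The series", "measured", "known", "first", "only" and "open" are said of these compounds alone.

Series notes. Compound 1 `COc1ccc(/C=C2\CN(C(=S)SCc3cn(Cc4ccccc4F)nn3)C/C(=C\c3ccc(OC)cc3)C2=O)cc1` and compound 2 `O=C1/C(=C/c2ccccc2F)CN(Cc2cn(Cc3ccccc3F)nn2)C/C1=C\c1ccccc1F` share a core; compound 3 `COc1ccc(/C=C2\CN(C(=S)SCc3cn(Cc4ccccc4Cl)nn3)C/C(=C\c3ccc(OC)cc3)C2=O)cc1` has no value yet. In a functional assay on MDA-MB-231 cells (Homo sapiens) for cytotoxicity, read by MTT assay, with a stated time of 24 h (on this read-out lower numbers stand for stronger inhibition and higher numbers for weaker inhibition), compound 1 gives > 100000 nM, which is a limit of the assay and not a number. In this assay compound 2 gives 16000 nM. Compound 1 thus stands at the limit of > 100000 nM in this assay, at which 1 of the 2 values shown sits, and its place among the values is known only as that limit. Compound 3 differs from compound 1 by chloro in place of fluoro on an aromatic carbon. Within the data shown here, no measured step speaks to this change; with compound 1 at the limit, the step of a number no higher from compound 1 to compound 3 (the limit leaves the size open) is expected to stay within the scatter. Compound 3 is estimated at 100000 nM, in the range 40000 nM to 300000 nM.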

Compound 3, half-maximal inhibitory concentration: > 100000 nM
Compound 3: only a limit was reported; the forecaster's own chance of this, stated with the estimate: 60%; the middle value lies on the limit itself.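

The step from compound 1 to compound 3 cannot be read in this assay, as both compounds stand at a limit of the assay, not at a number: the limit of > 100000 nM in this assay, at which 2 of the 3 values shown sit. The compounds shown leave open what chloro in place of fluoro does in a compound that gives a number in this assay.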